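This account rests on a few compounds, and the source may have more. Where it says the series, first, only, none or still open, it means among the compounds named here.

Measured compounds in an ADME assay on isolated protein for inhibition of Dipeptidyl peptidase 9 (Homo sapiens), with stated times of 15 min, 60 s and 20 min; on this read-out lower numbers stand for stronger inhibition and higher numbers for weaker inhibition:
compound 1 `CC#CCn1c(N2CCC[C@@H](N)C2)nc2c1c(=O)n(Cc1c(Br)cccc1C(=O)O)c(=O)n2C` — > 100000 nM
compound 2 `CC#CCn1c(N2CCC[C@@H](N)C2)nc2c1c(=O)n(Cc1ccc(Br)cc1C(=O)OC)c(=O)n2C` — > 100000 nM
compound 3 `CC#CCn1c(N2CCC[C@@H](N)C2)nc2c1c(=O)n(Cc1ccccc1C(=O)OC)c(=O)n2C` — > 100000 nM

Each value above is a limit of this assay and not a number. Compound 3 therefore stands only at a limit, and the two further values shown are limits as well, all sitting at the limit of > 100000 nM in this assay, at which 3 of the 3 values shown sit. No ordering among the three can be read from this.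

Compound 4 `CC#CCn1c(N2CCC[C@@H](N)C2)nc2c1c(=O)n(Cc1cc(Cl)ccc1C(=O)O)c(=O)n2C` is not yet measured. It differs from compound 3 by 2-carboxy-5-chlorophenyl in place of 2-(methoxycarbonyl)phenyl on a saturated chain carbon bound to an aromatic nitrogen. For the measured compounds named here, three measured steps touch the same region of the molecule: a step that the two limits leave unreadable from compound 1 to compound 3, a step that the two limits leave unreadable from compound 2 to compound 3 and a step that the two limits leave unreadable from compound 1 to compound 2. None of them has a readable size, since both ends of every pair sit at the limit (the limit of > 100000 nM in this assay, at which 3 of the 3 values shown sit). Compound 1 already carries a free carboxylic acid and a halogen on the aromatic ring and gives a limit, > 100000 nM. Nothing measured here points to a number appearing for compound 4.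

The expected step is a number no higher from compound 3 to compound 4 (the limit leaves the size open), that is none beyond the scatter, with compound 4 expected to return a limit again. The estimate for compound 4 in this assay is 100000 nM, with a range from 30000 nM to 300000 nM.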

Compound 4, half-maximal inhibitory concentration: > 100000 nM
Compound 4: only a limit was reported; the forecaster's own chance of this, stated with the estimate: 85%; the middle value sits exactly at the limit.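

Compound 4 returns only a limit and not a number in this assay, so none of its steps from compound 1, compound 2 or compound 3 can be read: the limit of > 100000 nM in this assay, at which 4 of the 4 values shown sit.

The compounds shown leave open the size of any change from the groups on the saturated chain carbon bound to an aromatic nitrogen, and whether any member of this series gives a number in this assay.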